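Swapping the halogenated ring for a benzodioxin

The compounds below may be only part of what the source reports. "The series", "measured", "known", "first", "only" and "open" are said of these compounds alone.

Compound 1 `CC(C(=O)NCc1ccc(C(F)(F)F)nc1-c1ccccc1)c1ccc(NS(C)(=O)=O)c(F)c1`: 6.4 nM
Compound 2 `CC(C(=O)NCc1ccc(C(F)(F)F)nc1-c1cccc(Cl)c1)c1ccc(NS(C)(=O)=O)c(F)c1`: 0.5 nM
Compound 3 `CC(C(=O)NCc1ccc(C(F)(F)F)nc1-c1ccc(F)c(Cl)c1)c1ccc(NS(C)(=O)=O)c(F)c1`: 0.2 nM

In an assay on CHO cells for antagonist activity at transient receptor potential cation channel subfamily V member 1 (Homo sapiens), read by FLIPR (on this read-out higher numbers stand for weaker inhibition and lower numbers for stronger inhibition), compound 3 gives the lowest number of the three; compound 2 is nearest, with a 2.5-fold lower number from compound 2 to compound 3 (0.40 log units; beyond the scatter), and compound 1 furthest, with a 32-fold lower number from compound 1 to compound 3 (1.51 log units; beyond the scatter). Compound 4 `CC(C(=O)NCc1ccc(C(F)(F)F)nc1-c1ccc2c(c1)OCCO2)c1ccc(NS(C)(=O)=O)c(F)c1` has not yet been measured and differs from compound 3 in one place: 2,3-dihydro-1,4-benzodioxin-6-yl in place of 3-chloro-4-fluorophenyl on an aromatic carbon. Going by the values given here, the steps that bear on this are a 13-fold lower number from compound 1 to compound 2 (1.11 log units; beyond the scatter) and a 2.5-fold lower number from compound 2 to compound 3 (0.40 log units; beyond the scatter), both moving to lower numbers as the phenyl gains halogens. Compound 4 keeps a substituted ring at that position but carries neither halogen, so a modest shift back toward higher numbers is expected, a 5.0-fold higher number from compound 3 to compound 4 (0.70 log units; beyond the scatter). For compound 4 the estimate is 1 nM, within a range of 0.2 nM to 5 nM.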

Compound 4, inhibition constant: 5 nM
Beside the measured number, compound 4's estimate is 5.0-fold (0.70 log units) below it; measured number inside the range.
By their numbers in this assay, from the lowest: compound 3; then compound 2; then compounds 4 and 1 (each within the scatter of the next).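

In this assay, the 2,3-dihydro-1,4-benzodioxin-6-yl ring gives up the gain made by the halogens, with a 25-fold higher number from compound 3 to compound 4 (1.40 log units; beyond the scatter) and a 10-fold higher number from compound 2 to compound 4 (1.00 log units; beyond the scatter), while a 1.3-fold lower number from compound 1 to compound 4 (0.11 log units; within the scatter) leaves it level with plain phenyl. At this position, then, a substituted ring does not by itself bring a lower number: among these compounds, only the chloro-bearing rings of compound 2 and compound 3 do so, and compound 4 goes against any broader reading. Nothing measured here accounts for the loss.

As far as these compounds go, whether the ring oxygens or the fused ring itself matters stays open. A 3-methoxyphenyl or an indan-5-yl group at this position would separate the two.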